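The compounds below may be only part of what the source reports. "The series", "measured", "known", "first", "only" and "open" are said of these compounds alone.

Measured compounds:

- compound 1, `COc1cccc(OC(=O)c2ccccc2O)c1OC(=O)c1ccccc1O`: 50.5%
- compound 2, `O=C(Oc1ccc(Cl)cc1OC(=O)c1ccccc1O)c1ccccc1O`: 51.6%

Of the compounds shown here, two have been tested in a functional assay on NCI-H1299 cells (Homo sapiens) for inhibition, read by scintillation counting, with a stated time of 30 min, tested at 30 uM; on this read-out higher numbers stand for more inhibition at the one concentration tested (going by the name of the read-out) and lower numbers for less inhibition. Compound 1, `COc1cccc(OC(=O)c2ccccc2O)c1OC(=O)c1ccccc1O`, gives 50.5%. Compound 2, `O=C(Oc1ccc(Cl)cc1OC(=O)c1ccccc1O)c1ccccc1O`, gives 51.6%. These two values lie within the usual scatter of one another, so on the numbers shown compound 1 stands together with compound 2 rather than apart from it; the two numbers are level.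

The third compound, compound 3, `O=C(Oc1cccc(F)c1OC(=O)c1ccccc1O)c1ccccc1O`, has not yet been measured in this assay. It differs from compound 1 in one place: fluoro in place of methoxy on an aromatic carbon. Among the compounds with values here, no step between measured compounds involves this kind of change, so there is nothing to lean on beyond the two values already seen, which sit close together.

With that in mind, the step from compound 1 to compound 3 in this assay is expected to be small, no larger than the scatter, in either direction: a number 0.5 percentage points lower from compound 1 to compound 3 (within the scatter). Compound 3 is therefore estimated at 50%, with a range from 35% to 65%.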

Compound 3, a percentage reported as inhibition, at one concentration (the size of the read-out at that concentration, not a potency): 51%
For compound 3 the middle estimate is 1 percentage points below the measured one, within the range that was stated.
By their numbers in this assay, from the lowest: compounds 1, 3 and 2 (each within the scatter of the next).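

In this assay, putting fluoro in place of methoxy on an aromatic carbon, ortho to a large group and meta to a large group, gives a number 0.5 percentage points higher from compound 1 to compound 3 (within the scatter). Within the data shown here, this is the first direct look at this position: a group of two heavy atoms with one hydrogen-bond acceptor gives way to a single fluorine atom with no hydrogen-bond acceptor, and the read-out stays level, so for this pair the position accepts either group with no change that can be told from the scatter. No measurement shown gives a reason why the two groups read alike, so the result describes what happens at this position without explaining it.

One swap cannot show whether any group at this position could move the read-out beyond the scatter, and an amine, a carboxylic acid or a longer chain in the same place would put that to the test. From the compounds shown here alone, since the read-out is taken at one concentration and is not a potency, it also remains open whether compound 1 and compound 3 would stay level across a range of concentrations.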